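The source may hold more compounds than are shown below. What is called first, only, known or untested is meant among the compounds shown, and "the series" means these compounds.

Compound 1 `O=C(/C=C\Nc1ccc(F)cc1)c1cn(-c2ccccc2)nc1-c1ccccc1` and compound 2 `O=C(/C=C\Nc1ccc(Cl)cc1)c1cn(-c2ccccc2)nc1-c1ccccc1` share one core and differ only in that compound 2 has chloro in place of fluoro on an aromatic carbon. In a functional assay on HT-29 cells (Homo sapiens) for antiproliferative activity, read by MTT assay, with a stated time of 48 h (on this read-out lower numbers stand for stronger inhibition and higher numbers for weaker inhibition), compound 1 gives 6870 nM, and compound 2 gives 3610 nM; this is a 1.9-fold lower number from compound 1 to compound 2 (0.28 log units; within the scatter). Compound 3 `O=C(/C=C\Nc1ccc(F)cc1)c1cn(-c2ccccc2)nc1-c1ccc(Cl)cc1` differs from compound 1 by chloro in place of hydrogen on an aromatic carbon. In this assay compound 3 reached only a limit, > 50000 nM. Put beside compound 1, that is an at least 7.2-fold higher number from compound 1 to compound 3 (0.86 log units; beyond the scatter). Compound 4 `O=C(/C=C\Nc1ccc(Cl)cc1)c1cn(-c2ccccc2)nc1-c1ccc(Cl)cc1` has not been measured; it differs from compound 3 by chloro in place of fluoro on an aromatic carbon, the same change, at the same kind of place, as from compound 1 to compound 2. Because that earlier change gave a 1.9-fold lower number from compound 1 to compound 2 (0.28 log units; within the scatter), compound 4 is expected to give about 40000 nM, likely between 15000 nM and 120000 nM. The expected step is an at least 1.2-fold lower number from compound 3 to compound 4 (0.09 log units; that floor lies within the scatter), set beside the measured 1.9-fold lower number from compound 1 to compound 2 (0.28 log units; within the scatter).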

Compound 4, half-maximal inhibitory concentration: 4650 nM
Compound 4: the middle estimate sits 8.6-fold (0.93 log units) above what was measured; the measured number lies below the stated range.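

In this assay the change from (4-fluorophenyl)amino to (4-chlorophenyl)amino does not carry over in size from one core to the other, with an at least 10-fold lower number from compound 3 to compound 4 (1.03 log units; beyond the scatter) as the new step: the same change on two cores in this assay, a 1.9-fold lower number (0.28 log units; within the scatter) from compound 1 to compound 2 and an at least 10-fold lower number (1.03 log units; beyond the scatter) from compound 3 to compound 4, at least 5.6-fold (0.75 log units) apart, beyond the scatter of two such steps. Chloro in place of hydrogen on an aromatic carbon also behaves differently on the two cores, with a 1.3-fold higher number from compound 2 to compound 4 (0.11 log units; within the scatter) as the new step: the same change on two cores in this assay, an at least 7.2-fold higher number (0.86 log units; beyond the scatter) from compound 1 to compound 3 and a 1.3-fold higher number (0.11 log units; within the scatter) from compound 2 to compound 4, at least 5.6-fold (0.75 log units) apart, beyond the scatter of two such steps. Compound 3 gives only a limit, > 50000 nM, so the size of its steps is known only as a floor, and these compounds show that the two changes do not simply add up, not why.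

Still open, on these data alone, is whether this holds for other groups in place of the halogen, such as methoxy or nitrile, or an amine.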